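This account rests on a few compounds, and the source may have more. Where it says the series, first, only, none or still open, it means among the compounds named here.

Measured so far in an assay on isolated protein for activation of Nicotinamide phosphoribosyltransferase (Homo sapiens); on this read-out higher numbers stand for an effect only at larger amounts of compound and lower numbers for an effect already at smaller amounts:
- compound 2 `O=C(NCc1ccncc1)Nc1ccc(S(=O)(=O)N2CC3CCC(C2)O3)cc1`: 279 nM
- compound 3 `CCOC(=O)c1ccc(NC(=O)CCc2ccncc2)cc1`: 15900 nM
- compound 1 `CCOC(=O)c1ccc(NC(=O)N(C)Cc2ccncc2)cc1`: a limit, > 100000 nM

Compound 2 has the lowest of the two numbers in this assay; compound 3 gives 15900 nM, a clearly higher number than compound 2, so the two stand well apart. Compound 1 gives no number but only a limit of the assay, > 100000 nM; this is the one case of the limit of > 100000 nM in this assay, at which 1 of the 3 values shown sits. Among the compounds with values here, no pair among the three differs in one place, so no single change is isolated by the measured values.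

Compound 4 `O=C(NCc1ccncc1)Nc1ccc(S(=O)(=O)Nc2ccccc2)cc1` is not yet measured. It differs from compound 2 as follows: a group of 7 heavy atoms (6 carbon, 1 nitrogen; one six-membered aromatic ring of carbon only) in place of a group of 8 heavy atoms (6 carbon, 1 nitrogen, 1 oxygen; one five-membered non-aromatic ring with 1 hetero atom, one six-membered non-aromatic ring with 2 hetero atoms), on a sulfonyl sulfur. The urea and the pyridylmethyl part of compound 2 are retained, and the change sits only on the sulfonyl sulfur.

Within the data shown here, no comparable step is on record, so the expected size of the step from compound 2 to compound 4 can only be rough; a shift of about a 1.6-fold higher number from compound 2 to compound 4 (0.21 log units; within the scatter) is expected, a small loss at most, not far beyond the scatter. Compound 4 is therefore estimated at 450 nM in this assay, with a range from 100 nM to 2500 nM.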

Compound 4, half-maximal effective concentration: 410 nM
The estimate for compound 4 lay 1.1-fold (0.04 log units) above the measured number; the range from low to high includes it.
By their numbers in this assay, from the lowest: compounds 2 and 4 (each within the scatter of the next); then compound 3. At a limit, above all of these: compound 1.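

In this assay, within the data shown here, the first step that can be read is at the sulfonyl sulfur, where anilino takes the place of the group of 8 heavy atoms with its five-membered and six-membered non-aromatic rings: a 1.5-fold higher number from compound 2 to compound 4 (0.17 log units; within the scatter). This place therefore accepts an aromatic ring of carbon only as well as the two non-aromatic rings, and the exchange of 0 hydrogen-bond donors and 1 hydrogen-bond acceptor for 1 hydrogen-bond donor and 0 hydrogen-bond acceptors leaves compound 2 and compound 4 indistinguishable on this read-out, with the urea and the pyridylmethyl part held constant. No measured property among the data bears on this step, so its small size remains an observation without an explanation.

From the compounds shown here alone, how far this tolerance at the sulfonyl sulfur extends remains open, since a simple dimethylamino group, a morpholine or a carboxylic acid on the anilino ring could each behave differently from the two groups compared here. The contribution of the urea also remains unresolved, as no pair shown isolates a change at that part of the molecule.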